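The compounds below may be only part of what the source reports. "The series", "measured", "known", "first", "only" and "open" are said of these compounds alone.

Of the compounds shown here, three of one family have been tested in a functional assay on ileum (Cavia porcellus) for antagonist activity, with a stated time of 30 s; on this read-out lower numbers stand for stronger inhibition and higher numbers for weaker inhibition. Compound 1, with the structure `O=C(O)c1cc(=O)c2c(OCCOc3ccccc3)cccc2o1`, carries its side chain on one position of the shared core; in this assay compound 1 gives 100 ug/mL. Compound 2, with the structure `O=C(O)c1cc(=O)c2c(OCCCOc3ccccc3)cccc2o1`, differs from compound 1 by a single change, (phenoxymethyl in place of phenoxy on a saturated chain carbon, two bonds along the chain from an oxygen on an aromatic ring). That change produced the step of a 2.9-fold lower number from compound 1 to compound 2 (0.46 log units; beyond the scatter), so in this assay compound 2 gives 35 ug/mL. Compound 3, with the structure `O=C(O)c1cc(=O)c2ccc(OCCOc3ccccc3)cc2o1`, is built from the same atoms as compound 1 joined in a different way; how the two cores differ is not broken down here. In this assay compound 3 gives 15 ug/mL, the lowest of the three numbers, with compound 2 the nearest and compound 1 the furthest from it.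

Compound 4, with the structure `O=C(O)c1cc(=O)c2ccc(OCCCOc3ccccc3)cc2o1`, has not yet been measured. It stands to compound 3 as compound 2 stands to compound 1: the difference is phenoxymethyl in place of phenoxy on a saturated chain carbon, two bonds along the chain from an oxygen on an aromatic ring, the same change on the same kind of place. Among these four compounds that change has been seen once, and it is the whole basis for what follows.

Because the step of a 2.9-fold lower number from compound 1 to compound 2 (0.46 log units; beyond the scatter) lowered the number to a modest degree, a step of similar size is expected when the change is repeated on the core of compound 3, namely a 2.5-fold lower number from compound 3 to compound 4 (0.40 log units; beyond the scatter). For compound 4 in this assay the estimated value is 6 ug/mL, most likely falling between 2.5 ug/mL and 15 ug/mL.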

Compound 4, half-maximal inhibitory concentration: 1.4 ug/mL
Estimate against measurement, compound 4: 4.3-fold (0.63 log units) above; measured number outside the range, below it.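

In this assay, putting phenoxymethyl in place of phenoxy on the core of compound 3 gave an 11-fold lower number from compound 3 to compound 4 (1.03 log units; beyond the scatter), so the change lowered the number on this core just as it did on the core of compound 1. The direction of the step therefore carried over from one core to the other, but its size did not, as the two steps set side by side make clear: the same change on two cores in this assay, a 2.9-fold lower number (0.46 log units; beyond the scatter) from compound 1 to compound 2 and an 11-fold lower number (1.03 log units; beyond the scatter) from compound 3 to compound 4, 3.8-fold (0.57 log units) apart, beyond the scatter of two such steps. This shows that in this series the core on which the change sits matters for how large the step turns out, so a step measured on one core gave the direction on the other but not a reliable size; it does not show why the two cores respond differently, and with a single pair on each core it cannot say how the change would behave on a third core.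

The compounds shown leave open whether a still longer chain would lower the number further on either core, or whether the trend would reverse at some chain length. They also leave open what would happen if an amine took the place of the phenoxy end of the chain, or if an amide took the place of the carboxylic acid.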